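The source may hold more compounds than are shown below. What is called first, only, known or untested is meant among the compounds shown, and "the series" means these compounds.

Values in a functional assay on DLA cells (Mus musculus) for cytotoxicity, read by LDH release, with a stated time of 48 h; a lower number here means a stronger inhibitor, a higher number a weaker inhibitor:

- compound 1 `COc1ccc(-c2csc(NC(=O)COc3ccc(C(=O)c4ccccc4)cc3C)n2)cc1`: 26200 nM
- compound 2 `COc1ccc(-c2csc(NC(=O)COc3ccc(C(=O)c4ccc(C)cc4)cc3C)n2)cc1`: 18700 nM
- compound 3 `Cc1cc(C(=O)c2ccc(F)cc2)ccc1OCC(=O)Nc1nc(-c2ccccc2)cs1`: 34700 nM

The three values are close together. Compound 3 at 34700 nM lies within the scatter of both compound 1 and compound 2, so the numbers give it no separate standing in the series.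

The next comparison is compound 3 with compound 4 `COc1ccc(-c2csc(NC(=O)COc3ccc(C(=O)c4ccc(F)cc4)cc3C)n2)cc1`. The change is methoxy in place of hydrogen on an aromatic carbon. It turns phenyl into 4-methoxyphenyl, the group that compound 1 and compound 2 already carry.

Going by the values given here, no measured step covers this change directly. Among the compounds with values here, the only single-site step is a 1.4-fold lower number from compound 1 to compound 2 (0.15 log units; within the scatter), and it concerns methyl in place of hydrogen at a different site. It stays within the scatter, but it offers only weak guidance for a methoxy change. Compound 3 differs from compound 1 at more than one site, so the value of compound 1 at 26200 nM cannot isolate the effect of methoxy.

With so little evidence, no shift beyond the scatter is expected. The expected change is a 1.4-fold lower number from compound 3 to compound 4 (0.14 log units; within the scatter). For compound 4, the estimated value is 25000 nM, with an expected range of 14000 nM to 42000 nM.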

Compound 4, half-maximal inhibitory concentration: 5500 nM
For compound 4 the middle estimate is 4.5-fold (0.66 log units) above the measured one; the whole stated range lies above it.
By their numbers in this assay, from the lowest: compound 4; then compounds 2, 1 and 3 (each within the scatter of the next).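

Working notes: in this assay the change from phenyl to 4-methoxyphenyl gives a 6.3-fold lower number from compound 3 to compound 4 (0.80 log units; beyond the scatter) and so moves the series beyond the scatter, which the earlier compounds never did, and it shows that this aromatic carbon, para to a large group, is a site where a substitution registers. The other site also registers once methoxy is present: fluoro in place of hydrogen gives a 4.8-fold lower number from compound 1 to compound 4 (0.68 log units; beyond the scatter) and fluoro in place of methyl gives a 3.4-fold lower number from compound 2 to compound 4 (0.53 log units; beyond the scatter), whereas methyl in place of hydrogen at that same site gives only a 1.4-fold lower number from compound 1 to compound 2 (0.15 log units; within the scatter) and stays within the scatter. Nothing available on these compounds bears on why either change registers.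

The methoxy step is read only with fluoro present at the other site and the fluoro steps only with methoxy present, which leaves open whether the two changes act independently of each other. Also open, as far as these compounds go, is whether a different group at the methoxy position, such as an amine, a hydroxyl or a longer alkoxy chain like ethoxy, would give a step of similar size.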